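The source may hold more compounds than are shown below. What is called first, only, known or untested is meant among the compounds shown, and "the series" means these compounds.

Measured so far:
Compound 1, `CCOC(=O)c1cn(-c2ccccc2F)nc1CC(C)C`: > 100000 nM, a limit of the assay and not a number
Compound 2, `CCOC(=O)c1cn(-c2cccc(OC)c2)nc1CC(C)C`: 70500 nM

Within the data shown here, in a toxicity assay on HepG2 2.2.15 cells (Homo sapiens) for cytotoxicity, read by CCK-8 assay, with a stated time of 8 days (a higher number here means that more compound is tolerated, a lower number that less compound is tolerated), compound 2 gives 70500 nM, the only number obtained so far. Among the measured compounds shown here, the only other value to hand is the limit of > 100000 nM in this assay, at which 1 of the 2 values shown sits. For the measured compounds named here, no pair of measured compounds differing in one place exists, so the size of a single-group change in this assay cannot be read from the data.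

Compound 3, `CCOC(=O)c1cn(-c2cccc(C(=O)O)c2)nc1CC(C)C`, differs from compound 2 by carboxy in place of methoxy on an aromatic carbon. Going by the values given here, with no measured step to calibrate against, the expectation is that this change moves the half-maximal cytotoxic concentration upward, toward the limit, by the step of a 1.4-fold higher number from compound 2 to compound 3 (0.15 log units; within the scatter), a shift that may well not exceed the usual scatter. Compound 3 is accordingly estimated at 100000 nM, with a range from 40000 nM to 250000 nM, and a fair chance that only a limit is reported.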

Compound 3, half-maximal cytotoxic concentration: 7100 nM
The estimate for compound 3 lay 14-fold (1.15 log units) above the measured number; measured number below the stated range.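

In this assay, carboxy in place of methoxy on an aromatic carbon, meta to a large group, gives a 9.9-fold lower number from compound 2 to compound 3 (1.00 log units; beyond the scatter). Among these compounds, this is the first single-place step, and it shows that a change at this position can move the number beyond the scatter, here towards less compound being tolerated. Compound 1 stays a limit of the assay and not a number: the limit of > 100000 nM in this assay, at which 1 of the 3 values shown sits.

A single step cannot show whether the drop belongs to carboxy itself or would appear with other groups at this place, and an amine or a primary amide there would help separate those readings. On these data alone, whether the same exchange has a similar effect with the other aromatic substitution patterns also remains open.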